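Three Compounds at the Assay Ceiling and a Larger Amide

The source may hold more compounds than are shown below. What is called first, only, known or untested is meant among the compounds shown, and "the series" means these compounds.

Three measured compounds share one core and differ only in the substituent on the aryl ring attached to it. Compound 1 `COc1cccc(N2C(=O)N/C(=C\c3ccc(O)cc3)C2=O)c1` carries methoxy; in a functional assay on NCI-H292 cells (Homo sapiens) for antiproliferative activity (a lower number here means a stronger inhibitor, a higher number a weaker inhibitor), compound 1 gives > 200000 nM, which is a limit of the assay and not a number. Compound 2 `CCOC(=O)c1ccc(N2C(=O)N/C(=C\c3ccc(O)cc3)C2=O)cc1` in this assay gives > 200000 nM, again a limit. Compound 3 `O=C(O)c1cccc(N2C(=O)N/C(=C\c3ccc(O)cc3)C2=O)c1` carries carboxy in place of methoxy; in this assay compound 3 gives > 200000 nM, also a limit. Exchanging methoxy for carboxy yields a step that the two limits leave unreadable from compound 1 to compound 3. Every measured value is the limit of > 200000 nM in this assay, at which 3 of the 3 values shown sit, so compound 3 stands at the ceiling with no readable rank among the three.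

Compound 4 `O=C(Nc1ccc(Cl)cc1)c1cccc(N2C(=O)N/C(=C\c3ccc(O)cc3)C2=O)c1` differs from compound 3 by (4-chlorophenyl)amino in place of hydroxy on a carbonyl carbon. For the measured compounds named here, no measured step reaches beyond the limit, so nothing anchors the size or direction of this change. The expected step is an at least 2.0-fold lower number from compound 3 to compound 4 (0.30 log units; that floor lies within the scatter), a modest move toward stronger inhibition. Compound 4 is therefore estimated at 100000 nM, within 10000 nM to 200000 nM, with a real chance that the assay again reports only its limit.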

Compound 4, half-maximal inhibitory concentration: 125000 nM
Estimate against measurement, compound 4: 1.3-fold (0.10 log units) below; the range from low to high includes it.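

For the compounds shown here, on the carbonyl carbon, (4-chlorophenyl)amino in place of hydroxy brings the first reading in this assay that is a number and not a limit, with an at least 1.6-fold lower number from compound 3 to compound 4 (0.20 log units; that floor lies within the scatter). Set against the methoxy group of the earlier series, the (4-chlorophenyl)carbamoyl group gives an at least 1.6-fold lower number from compound 1 to compound 4 (0.20 log units; that floor lies within the scatter). Both steps are floors and not sizes, so what compound 4 firmly adds is a readable value, while the other compounds remain at the ceiling: the limit of > 200000 nM in this assay, at which 3 of the 4 values shown sit.

From the compounds shown here alone, how a plain phenylamino or a benzylamino group on the same carbonyl carbon would read stays open, so the part of the chlorine cannot be separated from that of the added ring. Also open, going by these compounds, is whether a sulfonamide in place of the amide linkage would keep a readable value.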